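The source may hold more compounds than are shown below. What is called first, only, known or untested is meant among the compounds shown, and "the series" means these compounds.

Measured so far:
compound 2, `O=c1cc(-c2ccccc2)oc2cc(OCc3ccccc3)c(OCCCN3CCCCC3)c(O)c12`: 3100 nM
compound 1, `O=c1cc(-c2ccccc2)oc2cc(O)c(OCCCCN3CCCC3)c(O)c12`: 51000 nM

Compound 2 gives the lower of the two numbers in a functional assay on A549 cells (Homo sapiens) for antiproliferative activity, read by MTT assay, with a stated time of 48 h; a lower number here means a stronger inhibitor, a higher number a weaker inhibitor; compound 1 sits well beyond the scatter from it. Compound 3, `O=c1cc(-c2ccccc2)oc2cc(O)c(OCCCN3CCCCC3)c(O)c12`, has not been measured there. It differs from compound 2 by hydrogen in place of benzyl on an oxygen on an aromatic ring. For the measured compounds named here, no single-change step between measured compounds supports this change directly, but compound 1, which also carries hydroxy, shows 51000 nM, so a weakening beyond the scatter is expected for compound 3, with a 3.9-fold higher number from compound 2 to compound 3 (0.59 log units; beyond the scatter). Compound 3 is therefore estimated at 12000 nM, within 4000 nM to 40000 nM.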

Compound 3, half-maximal inhibitory concentration: > 100000 nM
Compound 3 ended at the assay's limit; the forecaster's own chance of this, stated with the estimate: 5%; middle value at least 8.3-fold (0.92 log units) away from the limit.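

In this assay compound 3 gives > 100000 nM, which is a limit of the assay and not a number: the limit of > 100000 nM in this assay, at which 1 of the 3 values shown sits. With the chain and piperidine end held fixed, going from benzyloxy to hydroxy gives an at least 32-fold higher number from compound 2 to compound 3 (1.50 log units; beyond the scatter), so the activity of compound 2 depends on the benzyl on this oxygen, which the earlier pair, differing in two places, could not show. Between the two hydroxy compounds the step is an at least 1.9-fold higher number from compound 1 to compound 3 (0.29 log units; that floor lies within the scatter), which does not separate them.

On these data alone, it remains open whether a methyl or a phenethyl group on this oxygen would keep the activity of compound 2.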